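Ring substituent change next to the pyridine nitrogen: bromo

The source may hold more compounds than are shown below. What is called first, only, known or untested is meant among the compounds shown, and "the series" means these compounds.

The shared core of compound 1 `Cc1cccc(Nc2nc(-c3ccnc(CCCO)c3)cs2)c1` carries a 3-hydroxypropyl group on the six-membered aromatic ring with one nitrogen. In a functional assay on RCC4 cells (Homo sapiens) for inhibition, read by XTT assay, with a stated time of 4 days (on this read-out higher numbers stand for weaker inhibition and lower numbers for stronger inhibition), compound 1 gives 5250 nM, the only single number shown in this series; the remaining entries belong to compound 2 `Cc1cccc(Nc2nc(-c3ccnc(OCCCN(C)C)c3)cs2)c1`, which carries a different side chain at the same place and in this assay gives 6000 nM; 6030 nM (2 entries). Across these entries the two compounds sit close together, as the several entries of compound 2 show (the several entries of compound 2 in this assay, 6000 nM; 6030 nM (2 entries)).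

Compound 3 `Cc1cccc(Nc2nc(-c3ccnc(Br)c3)cs2)c1` has not yet been run in this assay. It differs from compound 1 in one place: bromo in place of 3-hydroxypropyl on an aromatic carbon, next to the ring nitrogen.

Among the measured compounds shown here, no measured step between two compounds of this kind is available, so the expectation rests on the two numbers above, which lie in a narrow band. The step from compound 1 to compound 3 is expected to be a 1.0-fold higher number from compound 1 to compound 3 (0.02 log units; within the scatter), that is none beyond the scatter. In this assay compound 3 is expected to give about 5500 nM, with a range from 2000 nM to 15000 nM.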

Compound 3, half-maximal inhibitory concentration: 2040 nM
For compound 3 the middle estimate is 2.7-fold (0.43 log units) above the measured one; measured number inside the range.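

In this assay, among the compounds shown here, the aromatic carbon next to the ring nitrogen proves sensitive to its substituent, which the two side chains of the earlier compounds did not reveal: bromo in place of 3-hydroxypropyl gives a 2.6-fold lower number from compound 1 to compound 3 (0.41 log units; beyond the scatter), a modest step. Neither the 4 heavy atoms of the 3-hydroxypropyl group nor its 1 hydrogen-bond donor and 1 hydrogen-bond acceptor are needed for inhibition here, as bromo, with 1 heavy atom and 0 hydrogen-bond donors or acceptors, gives the lower number. Repeat entries in this series agree closely, so a step of this size stands clear of repeat variation: the several entries of compound 2 in this assay, 6000 nM; 6030 nM (2 entries)

The change alters atom count, hydrogen-bond donors and hydrogen-bond acceptors together, so the compounds shown cannot say which of these goes with the step, and no property of bromo can be credited with it. A chloro or methyl group at this place would test whether a small substituent in general gives the same result, while a primary amine or a carboxylic acid would show how this position takes a charged group directly on the ring.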